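Morpholine to thiomorpholine on a shared thiocarbonyl core

The source may report more compounds than this note shows. Statements on the series, on what has been measured and on what is new or still open speak of the compounds shown alone.

The series begins with compound 1 `N/C(=N\NC(=S)N1CCOCC1)c1ccccn1`, which in a functional assay on A-431 cells (Homo sapiens) for cytotoxicity, read by MTT assay, with a stated time of 72 h (on this read-out higher numbers stand for weaker inhibition and lower numbers for stronger inhibition), gives 4800 nM. Compound 2 `Cc1ccnc(/C(N)=N/NC(=S)N2CCOCC2)c1` carries a methyl in place of hydrogen on an aromatic carbon, and in this assay compound 2 gives 6800 nM. The step of a 1.4-fold higher number from compound 1 to compound 2 (0.15 log units; within the scatter) is the only measured step, and it lies within the scatter, so compound 2 and compound 1 cannot be told apart on the numbers shown; compound 2 has no neighbour other than compound 1.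

The next compound is compound 3 `Cc1ccnc(/C(N)=N/NC(=S)N2CCSCC2)c1`, which differs from compound 2 by thiomorpholin-4-yl in place of morpholin-4-yl on a thiocarbonyl carbon. Within the data shown here, no measured step touches this part of the molecule: the one step available, a 1.4-fold higher number from compound 1 to compound 2 (0.15 log units; within the scatter), concerns a different site and was itself within the scatter. With nothing pointing in either direction, the expectation for this assay is a step no larger than the scatter, a 1.0-fold lower number from compound 2 to compound 3 (0.02 log units; within the scatter). On that basis compound 3 is estimated at 6500 nM in this assay, with a range from 3000 nM to 14000 nM.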

Compound 3, half-maximal inhibitory concentration: 7200 nM
For compound 3 the middle estimate is 1.1-fold (0.04 log units) below the measured one, within the range that was stated.
By their numbers in this assay, from the lowest: compounds 1, 2 and 3 (each within the scatter of the next).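

Thiomorpholin-4-yl in place of morpholin-4-yl on a thiocarbonyl carbon gives a 1.1-fold higher number from compound 2 to compound 3 (0.02 log units; within the scatter) in this assay, which extends the picture to a second site in the molecule, since the earlier step, a 1.4-fold higher number from compound 1 to compound 2 (0.15 log units; within the scatter), concerned an aromatic carbon. The two groups match in ring size, heavy-atom count and counts of hydrogen-bond donors and acceptors, differing in one ring atom, sulfur for oxygen, and that exchange does not separate compound 3 from compound 2 on the numbers. Neither single change in this short series moves beyond the scatter, and no independent evidence bears on this result.

Going by these compounds, it remains open whether a group that departs further from these two at the thiocarbonyl carbon, such as piperazin-1-yl, 4-methylpiperazin-1-yl or an open-chain dimethylamino group, would give a step beyond the scatter in this assay. On these data alone, it is also open whether thiomorpholin-4-yl would behave the same way on the core of compound 1, which lacks the methyl on the aromatic carbon.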